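From Cyclopentyl to 3-Cyanophenyl in a Toxicity Series

This account rests on a few compounds, and the source may have more. Where it says the series, first, only, none or still open, it means among the compounds named here.

Three compounds have so far been examined in a toxicity assay on THP-1 cells (Homo sapiens) for inhibition; on this read-out higher numbers stand for lower toxicity in this test and lower numbers for higher toxicity in this test. Compound 1 `COc1ccc2nc(NC(=O)c3ccc(F)cc3)n(C)c2c1` reaches only the limit of the assay, > 100000 nM. Compound 2 `Cn1c(-c2ccccc2)cnc1NC(=O)c1ncc[nH]1` likewise gives only the limit, > 100000 nM. Compound 3 `COc1ccc(-c2cnc(NC(=O)C3CCCC3)n2C)cc1` also returns only the limit, > 100000 nM. Compound 3 therefore stands exactly where its two companions stand: every value sits at the limit of > 100000 nM in this assay, at which 3 of the 3 values shown sit, and none of them is a number.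

Compound 4 `COc1ccc(-c2cnc(NC(=O)c3cccc(C#N)c3)n2C)cc1` has not yet been measured in this assay. It differs from compound 3 by 3-cyanophenyl in place of cyclopentyl on a carbonyl carbon. For the measured compounds named here, no step between two measured compounds exists here, so no measured change can guide the expectation. The step is expected to be a number no higher from compound 3 to compound 4 (the limit leaves the size open), none beyond the scatter. For compound 4 the estimate in this assay is 100000 nM, with a range from 40000 nM to 300000 nM, and most likely again only a limit.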

Compound 4, half-maximal cytotoxic concentration: > 100000 nM
Compound 4 ended at the assay's limit (the forecaster's own chance of this, stated with the estimate: 85%); the middle value sits exactly at the limit.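

No step can be read from compound 3 to compound 4, since both stop at a limit: the limit of > 100000 nM in this assay, at which 4 of the 4 values shown sit.

The compounds shown leave open whether 3-cyanophenyl in place of cyclopentyl changes anything in this assay, since none of them gives a number there.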